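This account rests on a few compounds, and the source may have more. Where it says the series, first, only, none or still open, it means among the compounds named here.

Working notes on the series. In a functional assay on THP-1 cells (Homo sapiens) for cytotoxicity, read by MTT assay, with a stated time of 72 h (on this read-out lower numbers stand for stronger inhibition and higher numbers for weaker inhibition), compound 1 (`C=C1CC[C@H]2C(C)(C)CCC[C@]2(C)[C@H]1CCC(C)CC(=O)O`) gives 132000 nM and compound 2 (`Cc1ccc(/C=C2\CC[C@H]3C(C)(C)CCC[C@]3(C)[C@H]2CCC(C)CC(=O)O)cc1`) gives 91000 nM so compound 2 stands level with compound 1 within the usual scatter. Compound 3 (`COc1ccc(/C=C2\CC[C@H]3C(C)(C)CCC[C@]3(C)[C@H]2CCC(C)CC(=O)O)cc1OC`) carries 3,4-dimethoxyphenyl in place of 4-methylphenyl on a double-bonded chain carbon bound to a double-bonded ring carbon, a change counted as 3,4-dimethoxyphenyl in place of 4-methylphenyl on a double-bonded chain carbon bound to a double-bonded ring carbon with the rest of the structure unchanged. For the measured compounds named here, no measured pair differing in one place is available, so this change has no direct precedent. In this assay no step beyond the scatter is expected in either direction. That expectation starts from compound 2 at 91000 nM and rests on so few data that the range is kept wide. The estimated step of a 1.1-fold lower number from compound 2 to compound 3 (0.06 log units; within the scatter) stays inside the scatter. Compound 3 is expected at 80000 nM with an estimated range from 35000 nM to 160000 nM in this read-out.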

Compound 3, half-maximal inhibitory concentration: 106000 nM
Compound 3: middle estimate off by 1.3-fold (0.12 log units), on the low side, and the stated range covers the measured number.
By their numbers in this assay, from the lowest: compounds 2, 3 and 1 (each within the scatter of the next).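

In this assay, 3,4-dimethoxyphenyl in place of 4-methylphenyl on a double-bonded chain carbon bound to a double-bonded ring carbon gives a 1.2-fold higher number from compound 2 to compound 3 (0.07 log units; within the scatter), which is a direct measured reading for a change at this position. The entering group adds heavy atoms and hydrogen-bond acceptors, yet the read-out does not separate the two compounds, so this assay does not distinguish these two substituted phenyl groups here. Nothing available explains this result.

Going by these compounds, it remains open whether a phenyl ring carrying a dimethylamino group or a nitrile at this position would give a step beyond the scatter. On these data alone, what an amide in place of the carboxylic acid would do in this assay also stays open.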